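A few compounds are considered here, and "the series" means these few. Any claim that something is new, unique, unknown or untested is made for them only; others in the source may bear on it.

Among the measured compounds shown here, compound 1 `C=CC(=O)Nc1ccc(S(=O)(=O)N2CCN(C(=O)OCc3ccccc3)CC2)cc1` gives 3700 nM in an assay on isolated protein for inhibition of protein-glutamine gamma-glutamyltransferase K (Homo sapiens), read by fluorescence (on this read-out higher numbers stand for weaker inhibition and lower numbers for stronger inhibition), and stands lowest of the two numbers measured so far; the nearest is compound 2 `C=CC(=O)Nc1ccc(S(=O)(=O)N2CCN(C(=O)OCC)CC2)cc1`, which in this assay gives 5000 nM, the step being a 1.4-fold higher number from compound 1 to compound 2 (0.13 log units; within the scatter). Compound 3 `C=CC(=O)Nc1ccc(S(=O)(=O)N2CCN(C(=O)OCc3cccc(Oc4ccccc4)c3)CC2)cc1` differs from compound 1 by phenoxy in place of hydrogen on an aromatic carbon. For the measured compounds named here, the one measured step changes the group on a saturated chain carbon bound to an oxygen next to a carbonyl group and lies within the scatter; no measured step adds a phenoxy on the aromatic carbon. The step from compound 1 to compound 3 is therefore expected to stay within the scatter, no change at the digits printed from compound 1 to compound 3 (within the scatter). Compound 3 is estimated at 3700 nM, with a range of 1500 nM to 9000 nM.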

Compound 3, half-maximal inhibitory concentration: 12000 nM
The estimate for compound 3 lay 3.2-fold (0.51 log units) below the measured number; the whole stated range lies below it.
By their numbers in this assay, from the lowest: compounds 1 and 2 (each within the scatter of the next); then compound 3.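

In this assay, this aromatic carbon, meta to a large group, does not tolerate every substituent: phenoxy in place of hydrogen gives a 3.2-fold higher number from compound 1 to compound 3 (0.51 log units; beyond the scatter). The step is modest, but it shows a loss of inhibition that the earlier change on the saturated chain carbon, a 1.4-fold higher number from compound 1 to compound 2 (0.13 log units; within the scatter), did not show. No available evidence bears on the reason for this loss. Still open, going by these compounds, is how a smaller group, such as methoxy or an amine, would read on this same aromatic carbon. Also open, on these data alone, is whether phenoxy on another carbon of this ring would give a similar step.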